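This account rests on a few compounds, and the source may have more. Where it says the series, first, only, none or still open, it means among the compounds named here.

Compound 2 `O=C(OCC1COCCOCCOCCOCCOCCO1)c1cccnc1` sits at the limit of > 100000 nM in this assay, at which 1 of the 2 values shown sits, in a functional assay on HBL-100 cells (Homo sapiens) for inhibition, read by sulforhodamine B assay, with a stated time of 48 h; on this read-out higher numbers stand for weaker inhibition of growth and lower numbers for stronger inhibition of growth. In this assay compound 2 reads > 100000 nM, which is a limit rather than a number. For the measured compounds named here, compound 1 `O=C(/C=C/c1ccccc1)OCC1COCCOCCOCCOCCOCCO1` gives 57000 nM in this assay, and the single measured step is an at least 1.7-fold higher number from compound 1 to compound 2 (0.24 log units; that floor lies within the scatter). Compound 3 `O=C(CCCCc1ccccc1)OCC1COCCOCCOCCOCCOCCO1` differs from compound 2 by 4-phenylbutyl in place of pyridin-3-yl on a carbonyl carbon. Because compound 1 gives 57000 nM with a phenyl-bearing group on the carbonyl carbon, a return toward that number is expected for compound 3, an at least 1.6-fold lower number from compound 2 to compound 3 (0.22 log units; that floor lies within the scatter). For compound 3 a value of 60000 nM is estimated, between 25000 nM and 150000 nM.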

Compound 3, concentration for 50% growth inhibition: 69000 nM
Estimate against measurement, compound 3: 1.2-fold (0.06 log units) below; the measured number falls inside the stated range.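

In this assay, 4-phenylbutyl and 2-phenylethenyl on the carbonyl carbon cannot be told apart, with a 1.2-fold higher number from compound 1 to compound 3 (0.08 log units; within the scatter). Putting 4-phenylbutyl in place of pyridin-3-yl gives an at least 1.4-fold lower number from compound 2 to compound 3 (0.16 log units; that floor lies within the scatter), so no real change can be claimed for that swap. Compound 2 gives a limit, not a number: the limit of > 100000 nM in this assay, at which 1 of the 3 values shown sits.

From the compounds shown here alone, it remains open whether the phenyl ring on these chains matters at all, and how far the number would move with an amine or a carboxylic acid at the end of the chain, or with a longer chain.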